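The source may report more compounds than this note shows. Statements on the series, on what has been measured and on what is new or still open speak of the compounds shown alone.

Working notes on the series. In an assay on CHO cells for displacement of a labelled ligand from adenosine receptor A1 (Homo sapiens), read by scintillation counting, with a stated time of 1 h, tested at 1 uM (a lower number here means less inhibition, a higher number more inhibition at the concentration tested (going by the name of the read-out)), compound 1 `Nc1ncc(-c2cccc(Cl)c2)c(-c2ccccc2)n1` reports a limit of the assay, > 80%. Compound 2 `COc1cccc(-c2cnc(N)nc2-c2ccccc2)c1` likewise gives only a limit in this assay, > 80%. For the measured compounds named here, compound 3 `CNc1ncc(-c2cccc(Cl)c2)c(-c2ccccc2)n1` gives the single plain number in this assay, 75%. Going by the values given here, the step of a number at least 5 percentage points lower from compound 1 to compound 3 (that floor lies within the scatter) is the one change made at the nitrogen on the aromatic ring, whereas a step that the two limits leave unreadable from compound 1 to compound 2 sits elsewhere and stays unreadable because both of its ends rest at the limit of > 80% in this assay, at which 2 of the 3 values shown sit. Compound 4 `Clc1cccc(-c2cnc(NCc3ccccc3)nc2-c2ccccc2)c1` differs from compound 3 by phenyl in place of hydrogen on a saturated chain carbon bound to a nitrogen on an aromatic ring. Among the compounds with values here, the nearby step, methyl in place of hydrogen, is the only guide; a larger group at that carbon is untested, so a modest drop is expected. For compound 4 the expected inhibition is 65%, with a range of 35% to 85%. This corresponds to an estimated step of a number 10 percentage points lower from compound 3 to compound 4 (within the scatter).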

Compound 4, a percentage reported as inhibition, at one concentration (the size of the read-out at that concentration, not a potency): 16%
Beside the measured number, compound 4's estimate is 49 percentage points above it; measured number below the stated range.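

For the compounds shown here, at this saturated chain carbon bound to a nitrogen on an aromatic ring, phenyl in place of hydrogen gives the first readable change beyond the scatter in this assay, a number 59 percentage points lower from compound 3 to compound 4 (beyond the scatter). The earlier methyl step on that nitrogen had shown only a floor within the scatter, whereas benzyl there gives a number at least 64 percentage points lower from compound 1 to compound 4 (beyond the scatter). That step is also only a floor, as one end is a limit: the limit of > 80% in this assay, at which 2 of the 4 values shown sit.

Going by these compounds, whether this drop is specific to phenyl or extends to other groups at that carbon stays open. Cyclohexyl or a longer chain there would test this, and neither is among the compounds shown.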